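A few compounds are considered here, and "the series" means these few. Any claim that something is new, unique, unknown or untested is made for them only; others in the source may bear on it.

Compound 1 `COc1ccc(-c2nc(CNc3ccc(C(=O)NO)cc3)n(-c3ccccc3)n2)cc1` gives the lowest number of the three measured in an assay on Sf9 cells for inhibition of protein deacetylase HDAC6 (Homo sapiens), read by fluorescence, with a stated time of 40 min (a lower number here means a stronger inhibitor, a higher number a weaker inhibitor), at 163 nM. Compound 2 `O=C(NO)c1ccc(NCc2nc(-c3ccccc3)nn2-c2ccccc2Cl)cc1` gives 669 nM and compound 3 `O=C(NO)c1ccc(NCc2nc(-c3ccccc3)nn2-c2cccc(Cl)c2)cc1` gives 678 nM, each beyond the scatter from compound 1. Among the measured compounds shown here, the only measured step between compounds differing in one place, a 1.0-fold higher number from compound 2 to compound 3 (0.01 log units; within the scatter), alters a group on an aromatic nitrogen, not the place altered here. Compound 4 `O=C(NO)c1ccc(NCc2nc(-c3ccc(F)cc3)nn2-c2ccccc2)cc1` differs from compound 1 by fluoro in place of methoxy on an aromatic carbon. For the measured compounds named here, no measured step concerns this place, so the numbers give no direction; the change is expected to stay within the scatter, perhaps with a slight weakening. Compound 4 is therefore estimated at 250 nM, with a range from 100 nM to 600 nM, meaning a step of a 1.5-fold higher number from compound 1 to compound 4 (0.19 log units; within the scatter).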

Compound 4, half-maximal inhibitory concentration: 115 nM
Beside the measured number, compound 4's estimate is 2.2-fold (0.34 log units) above it; the range from low to high includes it.
By their numbers in this assay, from the lowest: compounds 4 and 1 (each within the scatter of the next); then compounds 2 and 3 (each within the scatter of the next).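

Among the compounds shown here, the step from 4-methoxyphenyl to 4-fluorophenyl, a 1.4-fold lower number from compound 1 to compound 4 (0.15 log units; within the scatter), gives the first reading at this place, and in this assay the two groups cannot be told apart. Fluoro, with fewer heavy atoms and no hydrogen-bond acceptor, therefore serves here as well as methoxy. Nothing available explains this result. Going by these compounds, whether an amine, a carboxylic acid or a longer chain would also fit at this place stays open. On these data alone, compound 2 and compound 3 each differ from compound 4 in more than one place, so what their chloro groups contribute also stays open.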